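Swapping the aryl ether of a pyrazolone-free core to a fluoropyridine

The source may hold more compounds than are shown below. What is called first, only, known or untested is meant among the compounds shown, and "the series" means these compounds.

Three compounds share one core and differ only at the aryl ether or at the anilide. Compound 1 `O=C1c2cc(COc3ccc(F)cc3)nn2CCN1c1ccc(F)cc1` gives 72% in a functional assay on HEK293 cells for positive allosteric modulation of metabotropic glutamate receptor 5 (Homo sapiens), read by calcium flux; on this read-out lower numbers stand for smaller maximal responses and higher numbers for larger maximal responses; compound 2 `Cc1ccc(OCc2cc3n(n2)CCN(c2ccc(F)cc2)C3=O)cc1` gives 58%; compound 3 `O=C1c2cc(COc3ccncc3)nn2CCN1c1ccc(F)cc1` gives 69%, the second highest of the three numbers, close to compound 1 and clearly above compound 2. Compound 4 `O=C1c2cc(COc3ccc(F)cn3)nn2CCN1c1ccc(F)cc1` carries the change (5-fluoropyridin-2-yl in place of pyridin-4-yl on an oxygen on a saturated carbon). The two steps at the same oxygen, a number 3 percentage points lower from compound 1 to compound 3 (within the scatter) and a number 11 percentage points higher from compound 2 to compound 3 (beyond the scatter), were small to modest, so only a small shift in this assay is expected, with no clear direction beyond the scatter. Compound 4 is therefore estimated at 67% (range 55% to 79%), an expected step of a number 2 percentage points lower from compound 3 to compound 4 (within the scatter).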

Compound 4, largest response reached (Emax), in percent of the reference or control that the assay uses: 52%
Compound 4: the middle estimate sits 15 percentage points above what was measured, outside the stated range (below it).
By their numbers in this assay, from the lowest: compounds 4 and 2 (each within the scatter of the next); then compounds 3 and 1 (each within the scatter of the next).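

In this assay a pyridine ring on this oxygen does not by itself keep the response: the change to 5-fluoropyridin-2-yl gives a number 17 percentage points lower from compound 3 to compound 4 (beyond the scatter) and, set against the 4-fluorophenyl group, a number 20 percentage points lower from compound 1 to compound 4 (beyond the scatter). Only the 4-methylphenyl group stays close, with a number 6 percentage points lower from compound 2 to compound 4 (within the scatter). Nothing shown explains these steps. The 5-fluoropyridin-2-yl group differs from pyridin-4-yl both in the place of the ring nitrogen and in its fluorine, and this step does not separate the two. A plain pyridin-2-yl group on the same oxygen would part them.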